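Pyridinyl exchange on the tertiary amide side chain

The compounds below may be only part of what the source reports. "The series", "measured", "known", "first", "only" and "open" are said of these compounds alone.

Compound 2 `COc1ccc(-c2cccc(C(=O)N(C)Cc3ccccn3)c2)cc1S(=O)(=O)Nc1cccc(NCCNC(=O)c2cccc(C)c2)c1` gives 76% in a functional assay on CHO-RD-HGA16 cells for agonist activity at Orexin receptor type 2 (Homo sapiens), read by fluorescence and calcium flux, with a stated time of 30 min (a lower number here means a smaller maximal response, a higher number a larger maximal response), and compound 1 `COc1ccc(-c2cccc(C(=O)N(C)CCN(C)C)c2)cc1S(=O)(=O)Nc1cccc(NCCNC(=O)c2cccc(C)c2)c1` gives 85% in this assay, the two numbers lying within the scatter of each other. Compound 3 `COc1ccc(-c2cccc(C(=O)N(C)Cc3cccnc3)c2)cc1S(=O)(=O)Nc1cccc(NCCNC(=O)c2cccc(C)c2)c1` differs from compound 2 by pyridin-3-yl in place of pyridin-2-yl on a saturated chain carbon bound to an amide-type nitrogen. Among the measured compounds shown here, the only measured step, a number 9 percentage points lower from compound 1 to compound 2 (within the scatter), concerns a different replacement at the same place; no measured step covers exchanging one pyridinyl for the other. Nothing in these numbers points to a change beyond the scatter, so compound 3 is expected to show no change at the digits printed from compound 2 to compound 3 (within the scatter). Compound 3 is estimated at 76%, with a range from 60% to 90%.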

Compound 3, largest response reached (Emax), in percent of the reference or control that the assay uses: 75%
Compound 3: middle estimate off by 1 percentage points, on the high side; the range from low to high includes it.
By their numbers in this assay, from the lowest: compounds 3, 2 and 1 (each within the scatter of the next).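

In this assay, pyridin-3-yl in place of pyridin-2-yl on the saturated chain carbon bound to the amide-type nitrogen gives a number 1 percentage points lower from compound 2 to compound 3 (within the scatter), so the two pyridinyl groups cannot be told apart at this place. Against the (dimethylamino)methyl group the step is a number 10 percentage points lower from compound 1 to compound 3 (within the scatter), so both pyridinyl groups now lie within the scatter of compound 1. No evidence on why these numbers fall as they do is available.

Going by these compounds, it remains open whether pyridin-4-yl, plain phenyl or a carboxylic acid at this place would stay within that scatter. On these data alone, a longer chain carrying the pyridinyl ring is equally open.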